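This account rests on a few compounds, and the source may have more. Where it says the series, first, only, none or still open, it means among the compounds named here.

Series values in a functional assay on PC-9 cells (Homo sapiens) for inhibition, read by MTT assay, with a stated time of 72 h; on this read-out lower numbers stand for stronger inhibition and higher numbers for weaker inhibition:
- compound 1 `Cc1cc(Nc2cc(-c3ccccc3)[nH]n2)n2nc(SCc3c(Cl)cccc3Cl)nc2n1`: 5180 nM
- compound 2 `Cc1cc(Nc2cc(-c3ccccc3)[nH]n2)n2nc(SCc3ccccc3Br)nc2n1`: 5630 nM
- compound 3 `COc1ccc(CSc2nc3nc(C)cc(Nc4cc(-c5ccccc5)[nH]n4)n3n2)cc1`: 8110 nM

Compound 3 sits with the other two, and no measured gap separates them: the steps are a 1.6-fold higher number from compound 1 to compound 3 (0.19 log units; within the scatter) and a 1.4-fold higher number from compound 2 to compound 3 (0.16 log units; within the scatter). The next compound, compound 4 `Cc1cc(Nc2cc(-c3ccccc3)[nH]n2)n2nc(SCC3CC3)nc2n1`, carries cyclopropyl in place of 4-methoxyphenyl on a saturated chain carbon bound to a sulfur. Cut one bond further out, this reads 4-methoxybenzyl to cyclopropylmethyl.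

The nearest evidence is these same two steps, together with a 1.1-fold higher number from compound 1 to compound 2 (0.04 log units; within the scatter). All three exchange one substituted phenyl for another at this place, and none leaves the place without a phenyl. The data therefore show tolerance among phenyl groups only, and the cyclopropyl case is an extrapolation. No step beyond the scatter is expected in this assay, though a drift towards a higher number cannot be excluded.

The estimated step is a 1.2-fold higher number from compound 3 to compound 4 (0.09 log units; within the scatter). For compound 4 the expected value is 10000 nM, with an estimated range of 5000 nM to 25000 nM.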

Compound 4, half-maximal inhibitory concentration: > 50000 nM
Compound 4: only a limit was reported (the forecaster's own chance of this, stated with the estimate: 20%); middle value at least 5.0-fold (0.69 log units) away from the limit.
By their numbers in this assay, from the lowest: compounds 1, 2 and 3 (each within the scatter of the next). At a limit, above all of these: compound 4.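

In this assay compound 4 is reported only as a limit, not as a number: the limit of > 50000 nM in this assay, at which 1 of the 4 values shown sits.

The steps to it are an at least 6.1-fold higher number from compound 3 to compound 4 (0.78 log units; beyond the scatter), an at least 8.8-fold higher number from compound 2 to compound 4 (0.94 log units; beyond the scatter) and an at least 9.6-fold higher number from compound 1 to compound 4 (0.98 log units; beyond the scatter), so the tolerance seen among the substituted phenyl groups on the saturated chain carbon bound to a sulfur does not extend to cyclopropyl. Among the compounds shown here, this is the first exchange at this place that removes the aromatic ring, and the first step that lies beyond the scatter.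

Cyclopropyl differs from 4-methoxyphenyl both in ring type and in heavy-atom count, and the compounds shown do not separate the two. A cyclohexyl group, which keeps a saturated ring at a larger size, or a pyridyl ring, which keeps an aromatic ring, would bear on that question.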